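Dimethylphenyl to Difluorophenyl in a Cell Toxicity Series

The source may hold more compounds than are shown below. What is called first, only, known or untested is meant among the compounds shown, and "the series" means these compounds.

Compound 1 `COc1ccc2nc(C)cc(OCC(=O)Nc3cc(C)cc(C)c3)c2c1` is tested in a toxicity assay on HepG2 cells (Homo sapiens) for inhibition, read by CellTiter-Glo, with a stated time of 48 h (on this read-out lower numbers stand for stronger inhibition and higher numbers for weaker inhibition), where it gives 20000 nM. Among the two plain numbers here it sits as the higher one; compound 3 `COc1cc2nc(C)cc(OCC(=O)Nc3cc(C)cc(C)c3)c2cc1OC` gives 10000 nM, a step that is a 2.0-fold lower number from compound 1 to compound 3 (0.30 log units; within the scatter). Compound 2 `Cc1cc(C)cc(NC(=O)COc2cc(C)nc3ccc(OC(F)(F)F)cc23)c1` gives only a limit of the assay, > 100000 nM, and this is the limit of > 100000 nM in this assay, at which 1 of the 3 values shown sits. The step from compound 1 to compound 2 is an at least 5.0-fold higher number from compound 1 to compound 2 (0.69 log units; beyond the scatter).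

Compound 4 `COc1ccc2nc(C)cc(OCC(=O)Nc3cc(F)cc(F)c3)c2c1` has not been measured. It differs from compound 1 in one place: 3,5-difluorophenyl in place of 3,5-dimethylphenyl on an amide-type nitrogen. Neither measured step touches this ring, so no direct guide exists. The step to compound 3 stayed within the scatter, and the step to compound 2 ran toward weaker inhibition. A change near the size of the scatter, in either direction, is the most likely outcome. Compound 4 is therefore expected to give 30000 nM in this assay, with a range from 8000 nM to 100000 nM; the estimated step from compound 1 to compound 4 is a 1.5-fold higher number from compound 1 to compound 4 (0.18 log units; within the scatter).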

Compound 4, half-maximal inhibitory concentration: > 100000 nM
Compound 4: no number, only a limit (the forecaster's own chance of this, stated with the estimate: 30%); middle value at least 3.3-fold (0.52 log units) away from the limit.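

Replacing 3,5-dimethylphenyl with 3,5-difluorophenyl on the amide-type nitrogen gives an at least 5.0-fold higher number from compound 1 to compound 4 (0.69 log units; beyond the scatter) in this assay. Within the data shown here, the earlier steps changed only groups on the shared core, so this is the first sign that the ring on the amide-type nitrogen also matters for this read-out, even though the group entering has the same heavy-atom count as the group leaving. Compound 4 gives only a limit and not a number, and that limit is shared: the limit of > 100000 nM in this assay, at which 2 of the 4 values shown sit.

Still open, on these data alone, is how other groups on the amide-type nitrogen would behave, such as 3,5-dichlorophenyl or a phenyl ring carrying an amine. Also open, as far as these compounds go, is whether the same replacement on the core of compound 3 would shift the read-out in the same direction.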